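Hydrazone aryl swap on the shared core: pyridin-4-yl variant

The source may report more compounds than this note shows. Statements on the series, on what has been measured and on what is new or still open speak of the compounds shown alone.

Measured so far in a functional assay on the whole organism (strain Wistar) for inhibition, with Rattus norvegicus as the target, read by paw edema, with a stated time of 30 min, at a dose of 10 mg/kg by the intraperitoneal route; on this read-out higher numbers stand for more inhibition at the one dose given (going by the name of the read-out) and lower numbers for less inhibition:
- compound 1 `O=C(N/N=C/c1cccc(F)c1)c1cccnc1Nc1cccc(C(F)(F)F)c1` gives 58.3%
- compound 2 `COc1ccc(/C=N/NC(=O)c2cccnc2Nc2cccc(C(F)(F)F)c2)cc1` gives 50.4%

Within the data shown here, the only step measured so far, a number 7.9 percentage points lower from compound 1 to compound 2 (within the scatter), puts 4-methoxyphenyl in place of 3-fluorophenyl on the carbon with a double bond to nitrogen. On the numbers shown, compound 2 does not stand apart from compound 1; the two read-outs sit within the scatter of each other.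

Compound 3 `O=C(N/N=C/c1ccncc1)c1cccnc1Nc1cccc(C(F)(F)F)c1` is not yet measured. Its change from compound 2 is pyridin-4-yl in place of 4-methoxyphenyl on a carbon with a double bond to nitrogen. Among the measured compounds shown here, no measured step covers a pyridin-4-yl at this position; the one step in hand, from compound 1 to compound 2, was within the scatter and gives no ground for expecting a shift beyond it in this assay. The change is therefore expected to be about a number 0.4 percentage points lower from compound 2 to compound 3 (within the scatter).

Compound 3 is estimated at 50%, in the range 35% to 65%.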

Compound 3, a percentage reported as inhibition, in the whole organism at one dose (the size of the read-out at that dose, not a potency): 68.1%
Estimate against measurement, compound 3: 18.1 percentage points below; the measured number lies above the stated range.
By their numbers in this assay, from the lowest: compounds 2, 1 and 3 (each within the scatter of the next, the first and the last beyond it).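

In this assay, among these compounds, the group on the carbon with a double bond to nitrogen can now be seen to move the read-out: pyridin-4-yl in place of 4-methoxyphenyl gives a number 17.7 percentage points higher from compound 2 to compound 3 (beyond the scatter), the first step to lie beyond the scatter. Pyridin-4-yl in place of 3-fluorophenyl gives a number 9.8 percentage points higher from compound 1 to compound 3 (within the scatter), so compound 3 stands apart from compound 2 only, and compound 1 and compound 3 remain within the scatter of each other. No data in hand bear on what lies behind the larger step.

Open, going by these compounds, is whether pyridin-3-yl or pyridin-2-yl at this carbon would read like pyridin-4-yl, or whether the result is tied to this one ring. A phenyl ring carrying an amine or a carboxylic acid would also test how far the read-out at this position can move.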